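Shortening the tert-butyl end of compound 1 to methyl

The source may report more compounds than this note shows. Statements on the series, on what has been measured and on what is new or still open speak of the compounds shown alone.

- Compound 1 `Cc1c(OCCCCOc2ccc(F)c(C(=O)O)c2)ccc(C(=O)CC(C)(C)C)c1O` gives 83%
- Compound 2 `Cc1ccc(C(=O)O)cc1OCCCCOc1ccc(C(=O)CC(C)C)c(O)c1C` gives 96%
- Compound 3 `Cc1c(OCCCCOc2ccc(C(=O)CC(C)(C)C)c(O)c2C)cccc1C(=O)O` gives 89%

These numbers come from an ADME assay on a cell-free system (plasma, Rattus norvegicus) for metabolic stability, read by LC-MS, with a stated time of 60 min, tested at 100 uM; a higher number here means that more of the compound is left, a lower number that less of the compound is left. Compound 1, at 83%, lies within the scatter of compound 3 and lower than compound 2, a gap beyond the scatter. All three compounds remain largely intact.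

The unmeasured compound 4 `CCC(=O)c1ccc(OCCCCOc2ccc(F)c(C(=O)O)c2)c(C)c1O` differs from compound 1 in one place: methyl in place of tert-butyl on a saturated chain carbon bound to a carbonyl carbon.

Among the measured compounds shown here, only one measured step joins two compounds that differ in a single place: a number 6 percentage points higher from compound 1 to compound 3 (within the scatter). That step is small, but it alters a different part of the molecule, so it bears on this change only loosely. Compound 2 differs from compound 1 in more than one place, so its gap cannot be pinned on any single change. For the measured compounds named here, no measured pair isolates the tert-butyl change.

Starting from compound 1 at 83%, no step beyond the scatter is expected in this assay. The expected change is a slight rise, a number 5 percentage points higher from compound 1 to compound 4 (within the scatter). For compound 4 the estimated value is 88%, with an expected range from 74% to 100%.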

Compound 4, percent of the compound remaining: 96%
Beside the measured number, compound 4's estimate is 8 percentage points below it, within the range that was stated.
By their numbers in this assay, from the lowest: compounds 1, 3, 2 and 4 (each within the scatter of the next, the first and the last beyond it).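

In this assay, among the compounds shown here, putting methyl in place of tert-butyl on a saturated chain carbon bound to a carbonyl carbon gives a number 13 percentage points higher from compound 1 to compound 4 (beyond the scatter), the first step in this set that isolates a single change and goes beyond the scatter. For the compounds shown here, the earlier single-place step, a number 6 percentage points higher from compound 1 to compound 3 (within the scatter), lay within the scatter and concerned the other end of the molecule, so this result is the first sign that the number can move with the group at this position. The two groups differ here only in carbon count, with 4 carbons in tert-butyl and 1 in methyl, and neither carries a ring, a hydrogen-bond donor, a hydrogen-bond acceptor or a net charge, but no available evidence says what lies behind the step.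

The compounds shown leave open whether an ethyl or a cyclopropyl group in this place would give a number closer to that of compound 1 or to that of compound 4. They also leave open whether the same change would give a step of similar size with 3-carboxy-2-methylphenyl in place of 3-carboxy-4-fluorophenyl.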